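The compounds below may be only part of what the source reports. "The series", "measured", "known", "first", "only" and "open" are said of these compounds alone.

In an in vitro ADME assay on microsomes from liver (Homo sapiens) for metabolic stability (a higher number here means that the compound lasts longer, a lower number that the compound disappears faster), compound 1 (`CC(C)CC1n2cncc2CN(CC2CC2)S1(=O)=O`) gives 0.917 h. Compound 3 (`C[C@@H](c1ccc(Cl)cc1)N1Cc2cncn2C(CC2(C)COC2)S1(=O)=O`) gives 1.27 h, within the usual scatter of compound 1, whereas compound 2 (`CC(C)CC1n2cncc2CN(Cc2ccc(OC(F)(F)F)cc2)S1(=O)=O`) gives 0.117 h, lower than compound 1 and beyond that scatter. Compound 4 (`CC(C)CC1n2cncc2CN(C2CC2)S1(=O)=O`) has not yet been measured. It carries cyclopropyl in place of cyclopropylmethyl on a sulfonamide nitrogen in a ring. Within the data shown here, no measured pair isolates this kind of change, so, with only a small swap to judge by, no step beyond the scatter is expected in this assay. The estimated step is a 1.2-fold higher number from compound 1 to compound 4 (0.08 log units; within the scatter). For compound 4 the half-life is expected to be 1.1 h, with an estimated range of 0.5 h to 2.3 h.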

Compound 4, half-life: > 6.75 h
Compound 4 ended at the assay's limit; the forecaster's own chance of this, stated with the estimate: 3%; at least 6.1-fold (0.78 log units) between middle value and limit.
By their numbers in this assay, from the lowest: compound 2; then compounds 1 and 3 (each within the scatter of the next). At a limit, above all of these: compound 4.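

Among these compounds, this is the first pair to isolate this position in this assay, and cyclopropyl in place of cyclopropylmethyl gives an at least 7.3-fold higher number from compound 1 to compound 4 (0.86 log units; beyond the scatter). A small swap on this sulfonamide nitrogen is therefore enough to move the half-life beyond the scatter. Compound 4 stands at a limit of this assay, so the full size of the step cannot be read: the limit of > 6.75 h in this assay, at which 1 of the 4 values shown sits.

On these data alone, whether cyclopropyl is special, or a cyclobutyl or tert-butyl group on this nitrogen would do the same, stays open. So does whether the step holds with a longer chain in place of isobutyl.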